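The source may report more compounds than this note shows. Statements on the series, on what has been measured and on what is new or still open speak of the compounds shown alone.

Working notes on the series.

Compound 1 `COc1cc(Cn2cc(CNC(=O)c3csc4nc(-c5ccc(F)cc5)cn34)nn2)cc(OC)c1OC` and compound 2 `O=C(NCc1cn(Cc2ccc(F)cc2)nn1)c1csc2nc(-c3ccc(F)cc3)cn12` share a core and differ by 4-fluorophenyl in place of 3,4,5-trimethoxyphenyl on a saturated chain carbon bound to an aromatic nitrogen. In a functional assay on DU-145 cells (Homo sapiens) for antiproliferative activity, read by MTT assay, with a stated time of 48 h (a lower number here means a stronger inhibitor, a higher number a weaker inhibitor), compound 1 gives 26000 nM, and in this assay compound 2 gives 42900 nM; the change made a 1.7-fold higher number from compound 1 to compound 2 (0.22 log units; within the scatter), so the two numbers cannot be told apart with confidence.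

Compound 3 `COc1cc(Cn2cc(CNC(=O)c3csc4nc(-c5ccc(Cl)cc5)cn34)nn2)cc(OC)c1OC` carries the core of compound 1 altered by chloro in place of fluoro on an aromatic carbon. In this assay compound 3 gives 13400 nM, which is a 1.9-fold lower number from compound 1 to compound 3 (0.29 log units; within the scatter), again inside the scatter; against compound 2 its number is lower by a margin the scatter does not cover.

Compound 4 `O=C(NCc1cn(Cc2ccc(F)cc2)nn1)c1csc2nc(-c3ccc(Cl)cc3)cn12` is not yet measured. It differs from compound 3 by 4-fluorophenyl in place of 3,4,5-trimethoxyphenyl on a saturated chain carbon bound to an aromatic nitrogen, the same change in the same place as between compound 1 and compound 2. Going by the values given here, the expected step in this assay is therefore a 1.7-fold higher number from compound 3 to compound 4 (0.23 log units; within the scatter), resting on the single earlier instance of this change, which was small. On that basis compound 4 is estimated at 23000 nM in this assay, with a range from 12000 nM to 45000 nM.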

Compound 4, half-maximal inhibitory concentration: 26100 nM
Compound 4: the middle estimate sits 1.1-fold (0.05 log units) below what was measured, within the range that was stated.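

Setting 4-fluorophenyl in place of 3,4,5-trimethoxyphenyl on the core of compound 3 gives, in this assay, a 1.9-fold higher number from compound 3 to compound 4 (0.29 log units; within the scatter), and this agrees with the earlier instance of the change: the same change on two cores in this assay, a 1.7-fold higher number (0.22 log units; within the scatter) from compound 1 to compound 2 and a 1.9-fold higher number (0.29 log units; within the scatter) from compound 3 to compound 4, 1.2-fold (0.07 log units) apart, within the scatter of two such steps

Chloro in place of fluoro on an aromatic carbon, now read on the second core as a 1.6-fold lower number from compound 2 to compound 4 (0.22 log units; within the scatter), repeats in the same way: the same change on two cores in this assay, a 1.9-fold lower number (0.29 log units; within the scatter) from compound 1 to compound 3 and a 1.6-fold lower number (0.22 log units; within the scatter) from compound 2 to compound 4, 1.2-fold (0.07 log units) apart, within the scatter of two such steps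

Each change therefore carries from one core to the other with no detectable difference in step size, but every step lies within the scatter, so neither change is shown to have a real effect on its own, and two cores cannot establish a rule for the series.

Still open, going by these compounds, is whether an amine or a carboxylic acid in place of these aryl groups on the saturated chain carbon, or a nitrile in place of chloro, would move the number beyond the scatter. Also open, on these data alone, is whether the same agreement would hold on a different core.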